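A few compounds are considered here, and "the series" means these few. Any claim that something is new, unique, unknown or untested is made for them only; others in the source may bear on it.

Working notes on the series, read in a functional assay on MCF7 cells (Homo sapiens) for antiproliferative activity, read by MTT assay, with a stated time of 24 h; a lower number here means a stronger inhibitor, a higher number a weaker inhibitor. Of the compounds shown here, two sharing one core have been measured so far. Compound 1 (`COc1ccc(S(=O)(=O)n2c(-c3cn(-c4ccccc4)nc3-c3ccc(C(F)(F)F)cc3)nc3ccccc32)cc1`) gives 420 nM, and compound 2 (`O=S(=O)(c1ccc(Br)cc1)n1c(-c2cn(-c3ccccc3)nc2-c2ccc(C(F)(F)F)cc2)nc2ccccc21`) gives 2470 nM, the higher of the two numbers. Within the data shown here, the single measured step, with bromo in place of methoxy on an aromatic carbon, is a 5.9-fold higher number from compound 1 to compound 2 (0.77 log units; beyond the scatter), which lies beyond the scatter.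

Compound 3 (`O=S(=O)(c1ccc(C(F)(F)F)cc1)n1c(-c2cn(-c3ccccc3)nc2-c2ccc(C(F)(F)F)cc2)nc2ccccc21`) has not yet been measured. It follows from compound 2 by trifluoromethyl in place of bromo on an aromatic carbon, para to a large group: trifluoromethyl in place of bromo on an aromatic carbon. Among the measured compounds shown here, only one measured step bears on this change, and only indirectly. The expectation of a limited change rests on a 5.9-fold higher number from compound 1 to compound 2 (0.77 log units; beyond the scatter), which shows that a swap at this place can move the number, but it involves methoxy. For the measured compounds named here, no measured compound yet carries trifluoromethyl here. A step no larger than that one is expected, probably within the scatter, with only a weak lean towards a lower number.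

The expected change is a 1.2-fold lower number from compound 2 to compound 3 (0.09 log units; within the scatter). For compound 3 the estimated value is 2000 nM, with an expected range of 700 nM to 5500 nM.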

Compound 3, half-maximal inhibitory concentration: 1240 nM
The estimate for compound 3 lay 1.6-fold (0.21 log units) above the measured number, within the range that was stated.
By their numbers in this assay, from the lowest: compound 1; then compounds 3 and 2 (each within the scatter of the next).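

In this assay, trifluoromethyl in place of bromo on this aromatic carbon, para to a large group, gives a 2.0-fold lower number from compound 2 to compound 3 (0.30 log units; within the scatter) and so does not separate these two groups at this position, which the earlier pair could not show. Trifluoromethyl in place of methoxy gives a 3.0-fold higher number from compound 1 to compound 3 (0.47 log units; beyond the scatter) in the same direction as the bromo step, so methoxy now stands apart from two different groups rather than one, and compound 1 is the strongest of the three, with its steps to both others printed as beyond the scatter. No supporting data bear on why methoxy differs from bromo and trifluoromethyl here.

With only three groups at this position, the compounds shown leave open whether the advantage belongs to methoxy alone or extends to other oxygen-linked groups such as ethoxy or hydroxy, and how an amine or a carboxylic acid would read here. The rest of the shared core is identical across the three compounds, so they say nothing about how the 4-(trifluoromethyl)phenyl group on the core or its unsubstituted phenyl contributes to the number.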